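From 4-chlorophenyl to pyridin-4-yl in a small series

This account rests on a few compounds, and the source may have more. Where it says the series, first, only, none or still open, it means among the compounds named here.

In a functional assay on MCF7 cells (Homo sapiens) for antiproliferative activity, read by MTT assay, with a stated time of 48 h (a higher number here means a weaker inhibitor, a lower number a stronger inhibitor), compound 1 (`CN(C)CCNc1cc2c(cn1)cc(NC(=O)c1cc3ccccc3s1)c(=O)n2C`) gives 12000 nM and compound 2 (`CN(C)CCNc1cc2c(cn1)cc(NC(=O)c1ccc(Cl)cc1)c(=O)n2C`) gives 3090 nM as the lower of the two numbers. Compound 3 (`CN(C)CCNc1cc2c(cn1)cc(NC(=O)c1ccncc1)c(=O)n2C`) keeps the core of compound 2 but carries pyridin-4-yl in place of 4-chlorophenyl on a carbonyl carbon. Within the data shown here, the only measured step at this place is a 3.9-fold lower number from compound 1 to compound 2 (0.59 log units; beyond the scatter) and it offers a modest size but no direction for the new group. The expected move is modest and towards a higher number, an estimated 2.3-fold higher number from compound 2 to compound 3 (0.36 log units; beyond the scatter) with wide uncertainty. For compound 3 the expected value is 7000 nM (range 2500 nM to 20000 nM).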

Compound 3, half-maximal inhibitory concentration: 36600 nM
Estimate against measurement, compound 3: 5.2-fold (0.72 log units) below, and the stated range ends below it.
By their numbers in this assay, from the lowest: compound 2; then compound 1; then compound 3.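

Among these compounds, replacing 4-chlorophenyl with pyridin-4-yl gives a 12-fold higher number from compound 2 to compound 3 (1.07 log units; beyond the scatter), the largest step so far at this place in this assay. Pyridin-4-yl also compares poorly with 1-benzothiophen-2-yl, with a 3.1-fold higher number from compound 1 to compound 3 (0.48 log units; beyond the scatter), so among these three groups 4-chlorophenyl gives the lowest number and pyridin-4-yl the highest. Nothing available here explains this order.

The compounds shown leave open whether the step follows from losing the chlorine or from gaining the ring nitrogen. A plain phenyl or a pyridin-3-yl group on the same carbonyl carbon could help separate the two.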